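Swapping chloro for methoxy on a second core

A few compounds are considered here, and "the series" means these few. Any claim that something is new, unique, unknown or untested is made for them only; others in the source may bear on it.

In a functional assay on OVCAR-3 cells (Homo sapiens) (on this read-out higher numbers stand for weaker inhibition of growth and lower numbers for stronger inhibition of growth), the measured compounds are:
compound 1 `Cc1cc(C)c2c(O)cc(-c3ccc(Cl)cc3)nc2n1` with 18200 nM
compound 2 `COc1ccc(-c2cc(O)c3c(C)cc(C)nc3n2)cc1` with 32400 nM
compound 3 `Cc1cnc2nc(-c3ccc(Cl)cc3)cc(O)c2c1` with 2240 nM

Compound 2 differs from compound 1 by one change, (methoxy in place of chloro on an aromatic carbon), and that change made a 1.8-fold higher number from compound 1 to compound 2 (0.25 log units; within the scatter). Compound 3 shares the same aryl group as compound 1 but has a different core; how the two cores differ is not broken down here. Compound 3 gives the lowest number of the three, and its gaps to compound 1 and compound 2 lie beyond the usual scatter.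

Compound 4 `COc1ccc(-c2cc(O)c3cc(C)cnc3n2)cc1` is compound 3 with the same change, (methoxy in place of chloro on an aromatic carbon). Because compound 1 to compound 2 gave a 1.8-fold higher number from compound 1 to compound 2 (0.25 log units; within the scatter), a step of similar size is expected from compound 3 to compound 4, namely a 1.7-fold higher number from compound 3 to compound 4 (0.23 log units; within the scatter). Compound 4 is therefore estimated at 3800 nM, likely between 1500 nM and 10000 nM.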

Compound 4, concentration for 50% growth inhibition: 2950 nM
The estimate for compound 4 lay 1.3-fold (0.11 log units) above the measured number; measured number inside the range.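

In this assay, methoxy in place of chloro on an aromatic carbon gives a 1.3-fold higher number from compound 3 to compound 4 (0.12 log units; within the scatter), so on this second core, too, the step stays within the usual scatter. The two cores agree on this swap: the same change on two cores in this assay, a 1.8-fold higher number (0.25 log units; within the scatter) from compound 1 to compound 2 and a 1.3-fold higher number (0.12 log units; within the scatter) from compound 3 to compound 4, 1.4-fold (0.13 log units) apart, within the scatter of two such steps

Within the data shown here, this suggests that the swap carries from one of these cores to the other with little change in the number, but it rests on only two pairs and does not show that chloro and methoxy are interchangeable on every core.

Going by these compounds, only chloro and methoxy appear at this position, so it remains open how an amine, a carboxylic acid or a longer chain such as butoxy would behave there. On these data alone, it also remains open whether the same swap would give a similar step on a third core.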